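Inverting Both Stereocentres of Compound 2

The source may report more compounds than this note shows. Statements on the series, on what has been measured and on what is new or still open speak of the compounds shown alone.

In a functional assay on A549 cells (Homo sapiens) for inhibition, read by MTT assay, with a stated time of 72 h (on this read-out lower numbers stand for stronger inhibition and higher numbers for weaker inhibition), compound 1 (`CC1=NN(c2ccccc2)C(=O)[C@@]12C(=O)C=CC[C@@H]2c1ccccc1[N+](=O)[O-]`) gives 66400 nM, while compound 2 (`CC1=NN(c2ccccc2)C(=O)[C@@]12C(=O)C=CC[C@H]2c1ccc(C)cc1`) gives 6090 nM. Compound 2 therefore holds the lower of the two numbers, and the gap between them lies beyond the scatter. The next compound to be tested is compound 3 (`CC1=NN(c2ccccc2)C(=O)[C@]12C(=O)C=CC[C@@H]2c1ccc(C)cc1`), and its relation to compound 2 is purely one of configuration: the two compounds have the same atoms and bonds and differ only in configuration as drawn: 2 of 2 stereo elements differ (all stereocentres are inverted: mirror images); a stereocentre at a saturated ring carbon is drawn R in compound 2 and S in compound 3; a stereocentre at a saturated ring carbon is drawn S in compound 2 and R in compound 3. Within the data shown here, no measured pair here shows what such an inversion does, so the expectation remains loose. Among the measured compounds shown here, since compound 2 stands at 6090 nM, the better of only two numbers so far, a moderate move towards weaker inhibition is expected, although no change beyond the scatter remains possible. The expected size of this move is a 2.0-fold higher number from compound 2 to compound 3 (0.29 log units; within the scatter). For compound 3 the estimated value is 12000 nM, with an expected range from 4000 nM to 40000 nM.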

Compound 3, half-maximal inhibitory concentration: 8600 nM
The estimate for compound 3 lay 1.4-fold (0.14 log units) above the measured number; the measured number falls inside the stated range.
By their numbers in this assay, from the lowest: compounds 2 and 3 (each within the scatter of the next); then compound 1.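

In this assay, inverting both stereocentres gives a 1.4-fold higher number from compound 2 to compound 3 (0.15 log units; within the scatter), so this pair of mirror images cannot be told apart on this read-out. Compounds 1 and 2 could not show this, as they differ in their aryl substituents as well as in the configuration drawn at one stereocentre. Compounds 2 and 3 offer a comparison in which nothing but the drawn stereochemistry can account for the step: the fact that compounds 2 and 3 differ only in the configuration as drawn.

As far as these compounds go, whether configuration matters as little with other substituents, such as an amine or a carboxylic acid in place of the methyl group, remains open. From the compounds shown here alone, the effect of inverting only one of the two stereocentres, which would give a diastereomer rather than a mirror image, also remains open.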